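The source may report more compounds than this note shows. Statements on the series, on what has been measured and on what is new or still open speak of the compounds shown alone.

Of the compounds shown here, three built on one shared core have been measured in a functional assay on HCC 2998 cells (Homo sapiens) for cytotoxicity, read by sulforhodamine B assay, with a stated time of 48 h, tested at 100 uM; a higher number here means a weaker effect of the compound at the concentration tested, a lower number a stronger effect. Compound 1 `COc1ccc(-c2cc(/C=C/C(=O)c3ccc(N)cc3)[nH]n2)cc1` gives -93% in this assay. Compound 2 `COc1cc(-c2cc(/C=C/C(=O)c3ccc(Cl)c(Cl)c3)[nH]n2)cc(OC)c1OC` gives -50% in this assay, and compound 3 `COc1ccc(C(=O)/C=C/c2cc(-c3cc(OC)c(OC)c(OC)c3)n[nH]2)cc1` gives -82% in this assay. Among these numbers compound 2 stands highest, meaning the weakest effect of the three at the tested concentration; its nearest neighbour is compound 3, and compound 1 lies furthest below it, both gaps being beyond the scatter.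

Compound 4 `COc1cc(-c2cc(/C=C/C(=O)c3ccc(F)c(F)c3)[nH]n2)cc(OC)c1OC` has not yet been measured. It differs from compound 2 in a single place: 3,4-difluorophenyl in place of 3,4-dichlorophenyl on a carbonyl carbon. Within the data shown here, the one measured step at the same carbonyl carbon is a number 32 percentage points lower from compound 2 to compound 3 (beyond the scatter), where a 4-methoxyphenyl took the place of the 3,4-dichlorophenyl. Among the measured compounds shown here, the present change keeps two halogens on that ring and only exchanges their kind, so no measured step covers it directly and its direction remains uncertain. A modest fall in the number is nevertheless the expectation, the estimated step being a number 12 percentage points lower from compound 2 to compound 4 (beyond the scatter). Compound 4 is therefore estimated to give -62% in this assay, with a likely range from -90% to -32%.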

Compound 4, a percentage reported as activity, at one concentration (the size of the read-out at that concentration, not a potency): -11%
Compound 4: middle estimate off by 51 percentage points, on the low side, outside the stated range (above it).
By their numbers in this assay, from the lowest: compound 1; then compound 3; then compound 2; then compound 4.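

In this assay, the identity of the two halogens on the ring at the carbonyl carbon clearly matters: the change to fluorine gives a number 39 percentage points higher from compound 2 to compound 4 (beyond the scatter) and thus a weaker effect at the tested concentration, even though 3,4-dichlorophenyl and 3,4-difluorophenyl have the same counts of heavy atoms, rings, hydrogen-bond donors and acceptors, and the same lack of net charge. The earlier step at this position showed only a fall in the number, whereas this position is now seen to move the number in both directions, and the widest step at it is a number 71 percentage points higher from compound 3 to compound 4 (beyond the scatter) when 3,4-difluorophenyl replaces 4-methoxyphenyl. Nothing available here gives a reason for the difference between the two halogen pairs.

On these data alone, it remains open whether 3,4-dibromophenyl would continue the change seen from chlorine to fluorine, or whether a plain phenyl ring without any halogen would lie closer to compound 2 or compound 4. As far as these compounds go, it also remains open whether a single fluorine or a single chlorine on the ring would be enough to produce a large shift in this number.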